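A few compounds are considered here, and "the series" means these few. Any claim that something is new, unique, unknown or untested is made for them only; others in the source may bear on it.

Compound 1 `Cc1nc2cc(-c3cccc(OCc4ccccc4)c3)nn2c(-c2cc(F)c3c(c2C)CCCO3)c1C(OC(C)(C)C)C(=O)O`: 72%
Compound 2 `Cc1nc2cc(-c3cccc(-c4ccccc4)c3)nn2c(-c2cc(F)c3c(c2C)CCCO3)c1[C@H](OC(C)(C)C)C(=O)O`: 78%
Compound 3 `Cc1nc2cc(-c3cccc(-c4ccccc4)c3)nn2c(-c2cc(F)c3c(c2C)CCCO3)c1C(OC(C)(C)C)C(=O)O`: 86%

In an ADME assay on microsomes from liver (Homo sapiens), read by LC-MS, using NADPH, with a stated time of 10 min, tested at 0.5 uM (a lower number here means that less of the compound is left, a higher number that more of the compound is left), compound 2 gives 78%, which lies within the scatter of both compound 1 and compound 3. Compound 4 `COc1ccc(-c2cccc(-c3cc4nc(C)c([C@H](OC(C)(C)C)C(=O)O)c(-c5cc(F)c6c(c5C)CCCO6)n4n3)c2)cn1` differs from compound 2 at one place: 6-methoxypyridin-3-yl in place of phenyl on an aromatic carbon. Within the data shown here, only one measured step changes a group at this place: a number 14 percentage points higher from compound 1 to compound 3 (beyond the scatter), phenyl in place of benzyloxy. The other step, a number 8 percentage points higher from compound 2 to compound 3 (within the scatter), concerns only (the fact that one of compounds 2 and 3 is drawn with a defined configuration and the other without, at the place where they differ). Read in reverse, the first step suggests a modest fall on losing phenyl, so a small fall in this assay is expected, perhaps none beyond the scatter. The expected step is a number 8 percentage points lower from compound 2 to compound 4 (within the scatter). Compound 4 is estimated at 70%, with an expected range of 55% to 85%.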

Compound 4, percent of the compound remaining: 73%
Estimate against measurement, compound 4: 3 percentage points below; the measured number falls inside the stated range.
By their numbers in this assay, from the lowest: compounds 1, 4, 2 and 3 (each within the scatter of the next, the first and the last beyond it).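

In this assay, 6-methoxypyridin-3-yl in place of phenyl gives a number 5 percentage points lower from compound 2 to compound 4 (within the scatter). This place, meta to a large group, therefore accepts a larger ring with a hetero atom and two hydrogen-bond acceptors without a change beyond the scatter, and compounds 2 and 4 carry the same drawn configuration. Nothing measured here bears on the reason for this step.

The compounds shown leave open whether the ring nitrogen and the methoxy group matter separately. They also leave open how an amine or a carboxylic acid on the phenyl ring would fare at this place.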